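The source may report more compounds than this note shows. Statements on the series, on what has been measured and on what is new or still open speak of the compounds shown alone.

Measured so far:
compound 1, `COc1ncnc2c1c(-c1ccsc1)cn2[C@@H]1O[C@H](CO)[C@@H](O)[C@H]1O`, 2570 nM in a functional assay on CCRF-CEM cells (Homo sapiens), read by MTT assay, with a stated time of 72 h; on this read-out lower numbers stand for stronger inhibition and higher numbers for weaker inhibition
compound 2, `C#Cc1cn([C@@H]2O[C@H](CO)[C@@H](O)[C@H]2O)c2ncnc(OC)c12`, > 20000 nM

For compound 2 the value in this assay is only a limit of the assay (the limit of > 20000 nM in this assay, at which 1 of the 2 values shown sits). Compound 3, `COc1ncnc2c1c(I)cn2[C@@H]1O[C@H](CO)[C@@H](O)[C@H]1O`, differs from compound 2 by iodo in place of ethynyl on an aromatic carbon. Among the measured compounds shown here, the one measured step at this aromatic carbon is an at least 7.7-fold higher number from compound 1 to compound 2 (0.89 log units; beyond the scatter), which leaves the ethynyl compound at the limit; no measured step covers iodo at this place. A step back from the limit toward a number is expected, an at least 4.0-fold lower number from compound 2 to compound 3 (0.60 log units; beyond the scatter). Compound 3 is estimated at 5000 nM in this assay, with a range from 500 nM to 20000 nM.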

Compound 3, half-maximal inhibitory concentration: 1150 nM
The estimate for compound 3 lay 4.3-fold (0.64 log units) above the measured number, and the stated range covers the measured number.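

Among the compounds shown here, at this aromatic carbon, iodo is the first group to give a lower number than thiophen-3-yl in this assay, with a 2.2-fold lower number from compound 1 to compound 3 (0.35 log units; beyond the scatter). The change from ethynyl is larger, with an at least 17-fold lower number from compound 2 to compound 3 (1.24 log units; beyond the scatter), so the choice of group at this one carbon moves the read-out well beyond the scatter. Compound 2 remains a limit of the assay, not a number: the limit of > 20000 nM in this assay, at which 1 of the 3 values shown sits.

As far as these compounds go, how an amine, a bromo group or a longer chain at this carbon would compare with iodo stays open. All three compounds share the rest of the core, so nothing here speaks to changes elsewhere.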